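Benzyloxy benzamides: changing the substituent on the benzyl ring

A few compounds are considered here, and "the series" means these few. Any claim that something is new, unique, unknown or untested is made for them only; others in the source may bear on it.

Measured so far:
compound 1 `O=C(NCc1ccccc1)c1ccccc1OCc1ccccc1`, in an assay on lysate for inhibition of phosphatidylcholine:ceramide cholinephosphotransferase 2 (Homo sapiens), read by HPLC, with stated times of 30 min and 2 h (a higher number here means a weaker inhibitor, a lower number a stronger inhibitor), compound 1 gives 34200 nM.
compound 2 `O=C(NC1CCCNC1)c1ccccc1OCc1ccccc1Cl`, for compound 2 this assay reports only a limit, > 100000 nM.
compound 3 `O=C(Nc1cccnc1)c1ccccc1OCc1ccccc1Cl`, in this assay compound 3 gives 1100 nM.

Compound 3 gives the lowest of the two numbers in hand; compound 1 sits higher, and compound 2 contributes only a limit (the limit of > 100000 nM in this assay, at which 1 of the 3 values shown sits). Within the data shown here, the one single-point step, an at least 90-fold lower number from compound 2 to compound 3 (1.95 log units; beyond the scatter), concerns the group on the amide-type nitrogen and not the benzyl ring, so it says nothing directly about the change to compound 4.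

Compound 4 `N#Cc1cccc(COc2ccccc2C(=O)Nc2cccnc2)c1` differs from compound 3 by 3-cyanophenyl in place of 2-chlorophenyl on a saturated chain carbon bound to an oxygen on an aromatic ring. Among the measured compounds shown here, no measured pair isolates a change on this ring: compound 1 and compound 3 differ both there and at the amide nitrogen, so their gap cannot be split. For the measured compounds named here, with no precedent in this assay, the step is expected to be modest, leaning towards a higher number, and may well stay within the scatter. The expected step is a 2.3-fold higher number from compound 3 to compound 4 (0.36 log units; beyond the scatter) for compound 4. Compound 4 is therefore estimated at 2500 nM, within 600 nM to 12000 nM.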

Compound 4, half-maximal inhibitory concentration: 60700 nM
Compound 4: middle estimate off by 24-fold (1.39 log units), on the low side; measured number outside the range, above it.
By their numbers in this assay, from the lowest: compound 3; then compounds 1 and 4 (each within the scatter of the next). At a limit, above all of these: compound 2.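

With pyridin-3-yl held on the amide-type nitrogen in this assay, the group on the saturated chain carbon bound to an oxygen on an aromatic ring proves to be a sensitive position: the exchange gives a 55-fold higher number from compound 3 to compound 4 (1.74 log units; beyond the scatter) as a large change from this one place alone. Among these compounds, compound 3 and compound 4 form the first pair to isolate this group, so the gain seen on the amide side does not make the other end of the series tolerant of change, and the 2-chlorophenyl of compound 3 cannot be treated as freely replaceable. The step swaps 2-chlorophenyl for 3-cyanophenyl as a whole, so the identity of the substituent and where it sits cannot be separated, and nothing measured on these compounds gives a cause for the step.

Still open, going by these compounds, is which of the two matters: 3-chlorophenyl, 2-cyanophenyl or plain phenyl, each with pyridin-3-yl on the amide-type nitrogen, would divide the step. Also open, on these data alone, is how other groups on this ring would read in the same assay, such as a methoxy group, an amine or a carboxylic acid.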